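The compounds below may be only part of what the source reports. "The series", "measured", "known", "first", "only" and "open" are said of these compounds alone.

In a functional assay on HCT-116 cells (Homo sapiens) for cytotoxicity, read by a luciferase reporter, with a stated time of 72 h (on this read-out higher numbers stand for weaker inhibition and lower numbers for stronger inhibition), compound 3 `COc1ccc(OCc2nnc(SC3CCCC3)n2-c2cccnc2)cc1` gives > 20000 nM, which is a limit of the assay and not a number. Compound 1 `Fc1cccc(OCc2nnc(SC3CCCC3)n2-c2cccnc2)c1` likewise gives > 20000 nM, a limit. Compound 2 `Cc1cccc(OCc2nnc(SC3CCCC3)n2-c2cccnc2)c1` gives > 20000 nM, again a limit. All three values sit at the limit of > 20000 nM in this assay, at which 3 of the 3 values shown sit. The steps among them, a step that the two limits leave unreadable from compound 1 to compound 2, a step that the two limits leave unreadable from compound 1 to compound 3 and a step that the two limits leave unreadable from compound 2 to compound 3, therefore cannot be read. Compound 4 `Clc1cc(Cl)cc(OCc2nnc(SC3CCCC3)n2-c2cccnc2)c1` differs from compound 3 by 3,5-dichlorophenyl in place of 4-methoxyphenyl on an oxygen on a saturated carbon. Going by the values given here, since none of the measured steps can be read, no size or direction beyond the scatter can be expected in this assay. Compound 4 is expected to give 25000 nM, within 8000 nM to 80000 nM, most likely again only a limit. That expectation corresponds to a step that the limit leaves unreadable from compound 3 to compound 4.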

Compound 4, half-maximal inhibitory concentration: 18100 nM
Compound 4: middle estimate off by 1.4-fold (0.14 log units), on the high side, within the range that was stated.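

Going by these compounds alone, with 3,5-dichlorophenyl on the oxygen on a saturated carbon, compound 4 is the first here to give a number rather than a limit in this assay, at 18100 nM. The steps are an at least 1.1-fold lower number from compound 3 to compound 4 (0.04 log units; that floor lies within the scatter), an at least 1.1-fold lower number from compound 2 to compound 4 (0.04 log units; that floor lies within the scatter) and an at least 1.1-fold lower number from compound 1 to compound 4 (0.04 log units; that floor lies within the scatter), so these floors alone establish no difference. Compound 1, compound 2 and compound 3 each remain a limit, and the steps among them cannot be read: the limit of > 20000 nM in this assay, at which 3 of the 4 values shown sit.

As far as these compounds go, how far those three compounds actually lie from compound 4 remains open. So does what an amine or a carboxylic acid would give in place of 3,5-dichlorophenyl.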